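Moving the carboxylic acid on a bile acid receptor agonist

A few compounds are considered here, and "the series" means these few. Any claim that something is new, unique, unknown or untested is made for them only; others in the source may bear on it.

Compound 1, `CC(C)c1onc(-c2c(Cl)cccc2Cl)c1COc1ccc(N(C)C(=O)c2cccc(C(=O)O)c2)c(C(F)(F)F)n1`, in a functional assay on HEK293 cells for agonist activity at Bile acid receptor (Homo sapiens) (a higher number here means a larger maximal response, a lower number a smaller maximal response), compound 1 gives 35%.
Compound 2, `CC(C)c1onc(-c2c(Cl)cccc2Cl)c1COc1ccc(NCc2ccc(C(=O)O)cc2)c(C(F)(F)F)n1`, compound 2 gives 48%.
Compound 3, `CC(C)c1onc(-c2c(Cl)cccc2Cl)c1COc1ccc(N(C)Cc2cccc(C(=O)O)c2)c(C(F)(F)F)n1`, compound 3 gives 89%.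

Compound 3 stands highest of the three, with compound 2 nearest and compound 1 furthest, both beyond the scatter. Compound 4 is `CC(C)c1onc(-c2c(Cl)cccc2Cl)c1COc1ccc(N(C)Cc2ccc(OCC(=O)O)cc2)c(C(F)(F)F)n1`; the change is 4-(carboxymethoxy)phenyl in place of 3-carboxyphenyl on a saturated chain carbon bound to a nitrogen on an aromatic ring. Of the measured steps, a number 41 percentage points higher from compound 2 to compound 3 (beyond the scatter) touches the same acid position, but it also changes methyl on the nitrogen, so it bears only partly; a number 54 percentage points higher from compound 1 to compound 3 (beyond the scatter) concerns the linker and does not bear. A step downward in this assay is therefore expected, of uncertain size, a number 29 percentage points lower from compound 3 to compound 4 (beyond the scatter). Compound 4 is estimated at 60%, within 35% to 90%.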

Compound 4, largest response reached (reported as efficacy), in percent of the reference or control that the assay uses: 69%
For compound 4 the middle estimate is 9 percentage points below the measured one, within the range that was stated.
By their numbers in this assay, from the lowest: compound 1; then compound 2; then compound 4; then compound 3.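

Putting 4-(carboxymethoxy)phenyl in place of 3-carboxyphenyl on the saturated chain carbon lowers the response in this assay (a number 20 percentage points lower from compound 3 to compound 4 (beyond the scatter)), so this position accepts a second acid-bearing group at some cost. That group on the benzyl linker still outperforms the carbonyl-linked compound (a number 34 percentage points higher from compound 1 to compound 4 (beyond the scatter)).

The compounds shown do not separate the change in ring position from the carboxymethoxy chain itself, and they leave open how a tetrazole in place of the carboxylic acid would fare here. No evidence at hand accounts for either step.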